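Amino-sugar change on two cores against topoisomerase 1

This account rests on a few compounds, and the source may have more. Where it says the series, first, only, none or still open, it means among the compounds named here.

Compound 2 `C[C@@H]1O[C@@H](OCC#Cc2c(-c3ccccc3)oc3ccccc23)C[C@H](N)[C@H]1O` and compound 1 `C[C@@H]1O[C@@H](OCC#Cc2c(-c3ccccc3)oc3ccccc23)CC[C@@H]1N` share a core and differ in one place: a group of 8 heavy atoms (6 carbon, 1 nitrogen, 1 oxygen; one six-membered non-aromatic ring with 1 hetero atom) in place of a group of 9 heavy atoms (6 carbon, 1 nitrogen, 2 oxygen; one six-membered non-aromatic ring with 1 hetero atom), on an oxygen on a saturated carbon. In an assay on isolated protein for inhibition of DNA topoisomerase 1 (Homo sapiens), with a stated time of 30 min, tested at 100 uM (on this read-out lower numbers stand for less inhibition and higher numbers for more inhibition at the one concentration tested (going by the name of the read-out)), compound 2 gives 25.5%, and compound 1 gives 20.2%, a step of a number 5.3 percentage points lower from compound 2 to compound 1 (within the scatter). Compound 3 `C[C@@H]1O[C@@H](OCC#Cc2c(-c3ccccc3)[nH]c3ccccc23)C[C@H](N)[C@H]1O` carries a different core; the difference between the two cores is not broken down here. In this assay compound 3 gives 8.2%, the lowest of the three numbers. Compound 4 `C[C@@H]1O[C@@H](OCC#Cc2c(-c3ccccc3)[nH]c3ccccc23)CC[C@@H]1N` relates to compound 3 by the same change: a group of 8 heavy atoms (6 carbon, 1 nitrogen, 1 oxygen; one six-membered non-aromatic ring with 1 hetero atom) in place of a group of 9 heavy atoms (6 carbon, 1 nitrogen, 2 oxygen; one six-membered non-aromatic ring with 1 hetero atom), on an oxygen on a saturated carbon. That change is expected to give a number 4.2 percentage points lower from compound 3 to compound 4 (within the scatter), because on the other core it gave a number 5.3 percentage points lower from compound 2 to compound 1 (within the scatter). Compound 4 is expected to give 4%, with a likely range from -4% to 14%.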

Compound 4, a percentage reported as inhibition, at one concentration (the size of the read-out at that concentration, not a potency): 4%
Compound 4: middle estimate and measured number agree at the digits printed, within the range that was stated.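

In this assay the change to 5-amino-6-methyloxan-2-yl gives a number 4.2 percentage points lower from compound 3 to compound 4 (within the scatter). Set beside the step on the other core, the two agree: the same change on two cores in this assay, a number 5.3 percentage points lower (within the scatter) from compound 2 to compound 1 and a number 4.2 percentage points lower (within the scatter) from compound 3 to compound 4, 1.1 percentage points apart, within the scatter of two such steps. In these two pairs the change therefore carries from one core to the other without a visible difference, but neither step shows that the change itself moves the read-out, and two cores cannot speak for any further core.

The compounds shown leave open what a dimethylamino group or an acetamide would give in place of the amine on the six-membered non-aromatic ring. With a single concentration behind each number, they also leave open how the potencies of these compounds compare.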